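Compound 4: hydrogen in place of hydroxy on the chain

The compounds below may be only part of what the source reports. "The series", "measured", "known", "first", "only" and "open" are said of these compounds alone.

Three compounds have numbers in a functional assay on HCT-116 cells (Homo sapiens) for inhibition, read by colorimetric assay, with a stated time of 3 days; a lower number here means a stronger inhibitor, a higher number a weaker inhibitor:

compound 1, `O=C(CCCCCCNC(=O)C(O)(O)C(F)(F)F)Nc1nccs1`: 10800 nM
compound 2, `O=C(CCCCCCNC(=O)C(O)(O)C(F)(F)F)Nc1nc2ccccc2s1`: 2370 nM
compound 3, `COc1ccc(NC(=O)CCCCCCNC(=O)C(O)(O)C(F)(F)F)cc1`: 4520 nM

Compound 1 gives the highest number of the three. Its step to compound 2 is a 4.6-fold lower number from compound 1 to compound 2 (0.66 log units; beyond the scatter) and its step to compound 3 is a 2.4-fold lower number from compound 1 to compound 3 (0.38 log units; beyond the scatter), both beyond the scatter; the pair compound 2 and compound 3 shows a 1.9-fold higher number from compound 2 to compound 3 (0.28 log units; within the scatter), within the scatter. All three steps vary only the group on the amide-type nitrogen and leave the rest of the chain as it is.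

Compound 4, `O=C(CCCCCCNC(=O)C(O)C(F)(F)F)Nc1nccs1`, keeps the amide-type nitrogen substituent of compound 1 and alters the other end of the chain: hydrogen in place of hydroxy on a saturated chain carbon bound to a carbonyl carbon, an oxygen on a saturated carbon and a saturated chain carbon. Cut one bond further out, the change reads 2,2,2-trifluoro-1,1-dihydroxyethyl to 2,2,2-trifluoro-1-hydroxyethyl. Within the data shown here, no measured step touches this part of the molecule, so none bears directly on the step from compound 1 to compound 4; the measured steps show only that changes elsewhere shift the number by modest amounts. With nothing to calibrate against, the expectation is wide. Compound 4 is estimated at 30000 nM, with a range from 8000 nM to 150000 nM. This estimate means an expected step of a 2.8-fold higher number from compound 1 to compound 4 (0.44 log units; beyond the scatter), toward a weaker inhibitor, with a real chance that only a limit is reported.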

Compound 4, half-maximal inhibitory concentration: > 40000 nM
Compound 4: a limit, no number (the forecaster's own chance of this, stated with the estimate: 35%); at least 1.3-fold (0.12 log units) between middle value and limit.
By their numbers in this assay, from the lowest: compounds 2 and 3 (each within the scatter of the next); then compound 1. At a limit, above all of these: compound 4.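

The earlier steps shown here in this assay changed only the group on the amide-type nitrogen, whereas the change from 2,2,2-trifluoro-1,1-dihydroxyethyl to 2,2,2-trifluoro-1-hydroxyethyl at the other end of the chain gives an at least 3.7-fold higher number from compound 1 to compound 4 (0.56 log units; beyond the scatter). The result for compound 4 is a limit and not a number: the limit of > 40000 nM in this assay, at which 1 of the 4 values shown sits.

Among the compounds shown, this end of the chain therefore matters to the read-out: hydrogen in place of hydroxy on this saturated chain carbon moves the number toward a weaker inhibitor, the opposite direction to the steps from compound 1 to compound 2 and to compound 3, and the full size of the step stays unknown.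

Whether the same change carries the same penalty with 1,3-benzothiazol-2-yl or 4-methoxyphenyl on the amide-type nitrogen remains open, since the compounds shown pair it only with 1,3-thiazol-2-yl. Also open, as far as these compounds go, is how this end of the chain would read with an amine or a carboxylic acid in place of the 2,2,2-trifluoro-1,1-dihydroxyethyl group, or with a longer chain.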